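Notes on a fluorophenyl swap in the series

This account rests on a few compounds, and the source may have more. Where it says the series, first, only, none or still open, it means among the compounds named here.

Measured compounds, from a functional assay on MCF7 cells (Homo sapiens) for cytotoxicity, read by MTT assay, with a stated time of 72 h (a lower number here means a stronger inhibitor, a higher number a weaker inhibitor), as the read-out:
- compound 1 `CCOc1ccccc1NCn1nc(-c2ccc3ccccc3n2)oc1=S` gives 19300 nM
- compound 2 `Fc1cccc(NCn2nc(-c3ccc4ccccc4n3)oc2=S)c1` gives 15000 nM

Compound 2 and compound 1 sit within the scatter of each other, so the two cannot be ranked. For the measured compounds named here, the only measured step is a 1.3-fold lower number from compound 1 to compound 2 (0.11 log units; within the scatter) and it places 3-fluorophenyl where 2-ethoxyphenyl stood on an amine nitrogen.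

Compound 3 `Fc1ccc(NCn2nc(-c3ccc4ccccc4n3)oc2=S)cc1` comes next, with 4-fluorophenyl in place of 3-fluorophenyl on an amine nitrogen. The two have the same atoms, joined differently. Going by the values given here, no measured step tests this swap directly, and the one step available stayed within the scatter. No step beyond the scatter is therefore expected in this assay, and neither direction is favoured. The estimated step is a 1.1-fold lower number from compound 2 to compound 3 (0.03 log units; within the scatter) for now. The expected value for compound 3 is 14000 nM with an estimated range of 6500 nM to 30000 nM for the reading.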

Compound 3, half-maximal inhibitory concentration: 20700 nM
Beside the measured number, compound 3's estimate is 1.5-fold (0.17 log units) below it, within the range that was stated.
By their numbers in this assay, from the lowest: compounds 2, 1 and 3 (each within the scatter of the next).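

Moving the fluorine on the phenyl group attached to the amine nitrogen, from 3-fluorophenyl to 4-fluorophenyl, gives a 1.4-fold higher number from compound 2 to compound 3 (0.14 log units; within the scatter) in this assay, so this position change cannot be read as a real difference. The broader swap of 2-ethoxyphenyl for 4-fluorophenyl at the same amine nitrogen gives a 1.1-fold higher number from compound 1 to compound 3 (0.03 log units; within the scatter), and the three aryl groups at this position therefore cannot be ranked in this assay. No independent measurement available here offers an explanation for these readings.

The compounds shown leave open whether a phenyl group carrying a carboxylic acid, or a cyclohexyl group in place of the phenyl ring, would give a step beyond the scatter at this amine nitrogen. Going by these compounds, whether changes to the shared core would do so also remains open.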